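The source may hold more compounds than are shown below. What is called first, only, known or untested is meant among the compounds shown, and "the series" means these compounds.

Measured so far:
- compound 1 `CS(=O)(=O)N1CC2(CC2)C[C@H](C(=O)NO)[C@H]1C(=O)N1C=CC(c2ccccc2)CC1` gives 51 nM in an assay on isolated protein for binding affinity to disintegrin and metalloproteinase domain-containing protein 10 (Homo sapiens); on this read-out lower numbers stand for stronger inhibition and higher numbers for weaker inhibition
- compound 2 `Cc1cccc(C2=CCN(C(=O)[C@H]3NCC4(CC4)C[C@@H]3C(=O)NO)CC2)c1` gives 25 nM in this assay

Compound 2 holds the lowest of the two numbers; compound 1 sits higher, a gap beyond the usual scatter. Compound 3 `COc1cccc(C2=CCN(C(=O)[C@H]3NCC4(CC4)C[C@@H]3C(=O)NO)CC2)c1` differs from compound 2 by methoxy in place of methyl on an aromatic carbon — methoxy in place of methyl on an aromatic carbon. Among the compounds with values here, no measured pair shows this exchange, so its size is unknown; a step within the scatter, in either direction, is expected. For compound 3 the estimate in this assay is 30 nM, with a range of 12 nM to 75 nM. That amounts to an expected step of a 1.2-fold higher number from compound 2 to compound 3 (0.08 log units; within the scatter).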

Compound 3, half-maximal inhibitory concentration: 40 nM
Compound 3: middle estimate off by 1.3-fold (0.12 log units), on the low side; the measured number falls inside the stated range.
By their numbers in this assay, from the lowest: compounds 2, 3 and 1 (each within the scatter of the next, the first and the last beyond it).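

In this assay, within the data shown here, 3-methylphenyl to 3-methoxyphenyl gives a 1.6-fold higher number from compound 2 to compound 3 (0.20 log units; within the scatter), so at this place on the aromatic ring, meta to a large group, the added oxygen of methoxy produces no step that can be told from the scatter. Among these compounds, this is the first pair that differs in one place, and it covers this single exchange. Nothing at hand bears on what lies behind this result.

As far as these compounds go, whether an amine, a carboxylic acid or a longer chain at this place would move the number stays open. Also open, from the compounds shown here alone, is whether methoxy elsewhere on the aromatic ring would behave as it does here.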